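The source may report more compounds than this note shows. Statements on the series, on what has been measured and on what is new or still open speak of the compounds shown alone.

Measured compounds:
Compound 1 `O=C(O)c1cccc(C2=C(c3cc(Br)ccc3OCc3ccc(Cl)cc3)CCC2)c1`; in an assay on isolated protein for inhibition of prostaglandin E2 receptor EP3 subtype (Homo sapiens) (a higher number here means a weaker inhibitor, a lower number a stronger inhibitor), compound 1 gives < 3170 nM, which is a limit of the assay.
Compound 2 `O=C(O)c1cccc(C2=C(c3cc(Cl)ccc3OCc3ccccc3)CCC2)c1`; in this assay compound 2 gives < 3170 nM, again a limit.
Compound 3 `CSc1ccc(OCc2ccc(F)cc2)c(C2=C(c3cccc(C(=O)O)c3)CCC2)c1`; in this assay compound 3 gives < 3170 nM, also a limit.

Compound 2 therefore stands only at a limit, and no ordering among the three compounds can be read from the numbers, since (the limit of < 3170 nM in this assay, at which 3 of the 3 values shown sit). Going by the values given here, no pair of measured compounds differs in a single place, so no measured step is available.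

Compound 4 `CSc1ccc(OCc2ccccc2)c(C2=C(c3cccc(C(=O)O)c3)CCC2)c1` is the unmeasured member. It differs from compound 2 by methylsulfanyl in place of chloro on an aromatic carbon. Compound 3 also carries the methylsulfanyl group and gives < 3170 nM, a limit. On that basis the expected step from compound 2 to compound 4 in this assay is a step that the limit leaves unreadable from compound 2 to compound 4, no shift resolvable beyond the scatter, and most likely another limit rather than a number. Compound 4 is estimated at 1500 nM in this assay, with a range from 300 nM to 6000 nM.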

Compound 4, half-maximal inhibitory concentration: < 3170 nM
Compound 4: a limit, no number (the forecaster's own chance of this, stated with the estimate: 80%); the middle value lies beyond the limit too.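

Neither step into compound 4, from compound 2 or from compound 3, can be read in this assay, because the values are limits rather than numbers: the limit of < 3170 nM in this assay, at which 4 of the 4 values shown sit.

The compounds shown leave open how far any of them truly differs, including whether methylsulfanyl in place of chloro changes anything.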